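The compounds below may be only part of what the source reports. "The series", "measured", "known", "first", "only" and "open" are said of these compounds alone.

Among the compounds with values here, compound 2 `CCc1ccccc1NC(=O)N[C@@H](C)c1ccccc1` gives 95% in an ADME assay on the whole organism with Oryza sativa as the target, tested at 10 uM (a higher number here means a weaker effect of the compound at the concentration tested, a lower number a stronger effect), the highest of the three numbers so far, though not separable from compound 1 `CCc1ccccc1NC(=O)N[C@H](C)c1ccccc1`, which gives 92% in this assay. Compound 3 `C[C@@H](NC(=O)Nc1ccc(C(C)(C)C)cc1)c1ccccc1` gives 53% in this assay, clearly lower. Within the data shown here, the only single-point step measured, a number 3 percentage points higher from compound 1 to compound 2 (within the scatter), stays within the scatter, which fits (the fact that compounds 1 and 2 differ only in the configuration as drawn). Compound 4 `C[C@H](NC(=O)Nc1ccccc1I)c1ccccc1` differs from compound 2 by iodo in place of ethyl on an aromatic carbon. Among the measured compounds shown here, no measured step touches a change on the aromatic ring, so the expectation rests on the spread of the three values alone. Compound 4 is expected to give about 82% in this assay, within 55% to 100%. The expected step is a number 13 percentage points lower from compound 2 to compound 4 (beyond the scatter), with wide uncertainty.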

Compound 4, a percentage reported as activity, at one concentration (the size of the read-out at that concentration, not a potency): 98%
Compound 4: the middle estimate sits 16 percentage points below what was measured, and the stated range covers the measured number.
By their numbers in this assay, from the lowest: compound 3; then compounds 1, 2 and 4 (each within the scatter of the next).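

Iodo in place of ethyl on an aromatic carbon, ortho to a large group, gives a number 3 percentage points higher from compound 2 to compound 4 (within the scatter) in this assay, the first measured step at this position. The two groups, one of two carbons and one a single iodine, cannot be told apart here in this assay. Nothing available bears on why these two groups read alike.

As far as these compounds go, whether an amine, a carboxylic acid or a methoxy group on this aromatic carbon would move the number stays open. So does whether any group at this position can reach a clearly lower number.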